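Cyclohexyl for propyl on the amide nitrogen

A few compounds are considered here, and "the series" means these few. Any claim that something is new, unique, unknown or untested is made for them only; others in the source may bear on it.

Compound 1 `CCCNC(=O)CN(c1cc(Cl)ccc1OC)S(=O)(=O)c1ccccc1` carries a propyl group on its amide nitrogen. In a functional assay on SH-SY5Y cells (Homo sapiens), read by MTT assay, with a stated time of 24 h (a higher number here means that more compound is needed for the effect, a lower number that less compound is needed), compound 1 reached only the limit of the assay, > 20000 nM, which is where compound 1 stands: at the limit of > 20000 nM in this assay, at which 1 of the 3 values shown sits, and without a number of its own. Compound 2 `COc1ccc(Cl)cc1N(CC(=O)N1CCCCC1)S(=O)(=O)c1ccccc1` gives 14500 nM in this assay, and compound 3 `COc1ccc(Cl)cc1N(CC(=O)N(C1CCCCC1)C1CCCCC1)S(=O)(=O)c1ccccc1` gives 14300 nM. Among the compounds with values here, the single measured step here runs an at least 1.3-fold lower number from compound 1 to compound 2 (0.13 log units; that floor lies within the scatter), a shift that stays inside the scatter. Compound 4 `COc1ccc(Cl)cc1N(CC(=O)NC1CCCCC1)S(=O)(=O)c1ccccc1` is the next member; its difference from compound 1 is cyclohexyl in place of propyl on an amide-type nitrogen. Within the data shown here, the only measured step that bears on it is the one from compound 1 to compound 2, and it does not leave the scatter; compound 3, a tertiary amide, shows a value close to that of compound 2. No step beyond the scatter is therefore expected in this assay, and a limit rather than a number remains about as likely as not. Compound 4 is expected at 18000 nM, within a range of 9000 nM to 40000 nM. The expected step is an at least 1.1-fold lower number from compound 1 to compound 4 (0.04 log units; that floor lies within the scatter).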

Compound 4, half-maximal effective concentration: 17600 nM
For compound 4 the middle estimate is 1.0-fold (0.01 log units) above the measured one; low and high end bracket the measured number.
By their numbers in this assay, from the lowest: compounds 3, 2 and 4 (each within the scatter of the next). At a limit, above all of these: compound 1.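

In this assay, cyclohexyl in place of propyl on the amide-type nitrogen gives an amide that keeps the amide hydrogen and has a number of its own, with the step reading an at least 1.1-fold lower number from compound 1 to compound 4 (0.05 log units; that floor lies within the scatter). Hydrogen in place of one cyclohexyl reads a 1.2-fold higher number from compound 3 to compound 4 (0.09 log units; within the scatter) and cyclohexylamino in place of piperidin-1-yl reads a 1.2-fold higher number from compound 2 to compound 4 (0.08 log units; within the scatter), so keeping or losing the amide hydrogen shows no change beyond the scatter among these compounds. Compound 1 stays at a limit and has no number of its own: the limit of > 20000 nM in this assay, at which 1 of the 4 values shown sits.

Whether any replacement at this amide nitrogen can move the number beyond the scatter stays open, since every step shown lies inside it. As far as these compounds go, how a longer chain such as octyl, or a cyclohexyl bearing a carboxylic acid, would read in this assay also stays open.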